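The compounds below may be only part of what the source reports. "The series", "measured", "known", "first", "only" and "open" are said of these compounds alone.

Measured compounds:
- compound 1 `N#Cc1c(-c2ccco2)nc2c(c(-c3ccccc3)nn2-c2ccccc2)c1-c1ccc(O)cc1`: 15100 nM
- compound 2 `COc1ccc(-c2nc3c(c(-c4ccccc4)nn3-c3ccccc3)c(-c3ccc(O)cc3)c2C#N)cc1`: 1000 nM
- compound 3 `N#Cc1c(-c2ccc(F)cc2)nc2c(c(-c3ccccc3)nn2-c2ccccc2)c1-c1ccc(O)cc1`: 9900 nM

All three share one core and differ only in the group on one aromatic carbon. In a functional assay on RS4-11 cells (Homo sapiens) for antiproliferative activity, read by resazurin assay, with a stated time of 72 h (on this read-out lower numbers stand for stronger inhibition and higher numbers for weaker inhibition), compound 3 gives 9900 nM, the second highest of the three numbers; it sits close to compound 1, as a 1.5-fold lower number from compound 1 to compound 3 (0.18 log units; within the scatter) shows, and far from compound 2, as a 9.9-fold higher number from compound 2 to compound 3 (1.00 log units; beyond the scatter) shows.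

Compound 4 `Cc1ccc(-c2nc3c(c(-c4ccccc4)nn3-c3ccccc3)c(-c3ccc(O)cc3)c2C#N)cc1` is not yet measured. It differs from compound 3 by methyl in place of fluoro on an aromatic carbon. Within the data shown here, two measured steps bear on this: a 15-fold lower number from compound 1 to compound 2 (1.18 log units; beyond the scatter) and a 9.9-fold higher number from compound 2 to compound 3 (1.00 log units; beyond the scatter). Both say that a 4-methoxyphenyl gives a much lower number than either a furan-2-yl or a 4-fluorophenyl at this place. A methyl is a different group from a methoxy, so the direction is uncertain, but a moderate lowering toward compound 2 is expected in this assay, a 2.0-fold lower number from compound 3 to compound 4 (0.30 log units; within the scatter). Compound 4 is therefore estimated at 5000 nM, with a range from 1500 nM to 15000 nM.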

Compound 4, half-maximal inhibitory concentration: 2700 nM
Compound 4: the middle estimate sits 1.9-fold (0.27 log units) above what was measured, and the stated range covers the measured number.
By their numbers in this assay, from the lowest: compound 2; then compound 4; then compounds 3 and 1 (each within the scatter of the next).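

In this assay the change of one small group on the phenyl ring gives a 3.7-fold lower number from compound 3 to compound 4 (0.56 log units; beyond the scatter), so a 4-fluorophenyl and a 4-methylphenyl are not interchangeable at this place. Until now only the 4-methoxyphenyl stood apart, but the 4-methylphenyl takes a middle rank: there is a 5.6-fold lower number from compound 1 to compound 4 (0.75 log units; beyond the scatter) on one side and a 2.7-fold higher number from compound 2 to compound 4 (0.43 log units; beyond the scatter) on the other, which shows that the low number of compound 2 is not reached by methyl yet is partly approached. No measurement here explains this order.

The compounds shown leave open whether an ethyl, a longer chain or an amine at this place would go lower than the methoxy of compound 2. They also do not tell how any of these groups would behave elsewhere on the ring.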